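From 4-chlorobenzyl to (methoxycarbonyl)methyl on the shared core

This account rests on a few compounds, and the source may have more. Where it says the series, first, only, none or still open, it means among the compounds named here.

Measured so far in an assay on isolated protein for inhibition of alpha-ketoglutarate-dependent dioxygenase alkB homolog 3 (Homo sapiens), read by polymerase chain reaction, with a stated time of 1 h; a lower number here means a stronger inhibitor, a higher number a weaker inhibitor:
compound 1 `Cc1[nH]n(-c2nc3ccccc3[nH]2)c(=O)c1Cc1ccccc1Cl` gives > 10000 nM, a limit of this assay
compound 2 `Cc1[nH]n(-c2nc3ccccc3[nH]2)c(=O)c1Cc1cccc(Cl)c1` gives 540 nM
compound 3 `Cc1[nH]n(-c2nc3ccccc3[nH]2)c(=O)c1Cc1ccc(Cl)cc1` gives > 10000 nM, again a limit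

Compound 3 therefore stands at the limit, (the limit of > 10000 nM in this assay, at which 2 of the 3 values shown sit), and only compound 2 has a read number. The step of an at least 18-fold higher number from compound 2 to compound 3 (1.26 log units; beyond the scatter) is readable; the step that the two limits leave unreadable from compound 1 to compound 3 has limits at both ends. Compound 4 `COC(=O)Cc1c(C)[nH]n(-c2nc3ccccc3[nH]2)c1=O` has not been measured. It differs from compound 3 by methoxycarbonyl in place of 4-chlorophenyl on a saturated chain carbon bound to an aromatic carbon. Among the compounds with values here, no measured step touches a group of this kind: the readable steps of an at least 18-fold lower number from compound 1 to compound 2 (1.26 log units; beyond the scatter) and an at least 18-fold higher number from compound 2 to compound 3 (1.26 log units; beyond the scatter) only move a chlorine around the phenyl ring. The step of a number no higher from compound 3 to compound 4 (the limit leaves the size open) is thus an expectation resting on compound 3 alone. Compound 4 is estimated at 10000 nM, between 2000 nM and 30000 nM, with a repeat of the limit thought likely.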

Compound 4, half-maximal inhibitory concentration: 4300 nM
The estimate for compound 4 lay 2.3-fold (0.37 log units) above the measured number; the range from low to high includes it.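

In this assay, a ringless methoxycarbonyl on the saturated chain carbon still gives a read number, with an at least 2.3-fold lower number from compound 3 to compound 4 (0.36 log units; beyond the scatter) and an at least 2.3-fold lower number from compound 1 to compound 4 (0.36 log units; beyond the scatter). Compound 1 and compound 3 each stand at a limit, not a number: the limit of > 10000 nM in this assay, at which 2 of the 4 values shown sit. The 3-chlorophenyl group keeps a clear lead, with an 8.0-fold higher number from compound 2 to compound 4 (0.90 log units; beyond the scatter).

The compounds shown do not tell whether the gain belongs to the methoxycarbonyl group as such or only to the loss of the 2-chlorophenyl and 4-chlorophenyl groups. A carboxylic acid or a primary amide in its place, or a longer chain carrying methoxycarbonyl, would separate these readings.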